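A few compounds are considered here, and "the series" means these few. Any claim that something is new, unique, unknown or untested is made for them only; others in the source may bear on it.

Working notes on the series.

Compound 2 `CC(C)c1cccc(C(C)C)c1NC(=O)NCC1(c2ccc(F)cc2)CCCC1` gives in an assay on microsomes for inhibition of acyl-CoA:cholesterol acyltransferase (Oryctolagus cuniculus) (on this read-out higher numbers stand for weaker inhibition and lower numbers for stronger inhibition), a value of 23 nM. Compound 1 `Cc1ccc(C2(CNC(=O)Nc3c(C(C)C)cccc3C(C)C)CCCC2)cc1` carries a methyl where compound 2 carries fluoro; in this assay compound 1 gives a value of 25 nM; the step of a 1.1-fold lower number from compound 1 to compound 2 (0.04 log units; within the scatter) is within the scatter, so the two measured numbers do not separate and compound 2 stands level with compound 1 on the numbers shown.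

Compound 3 `CC(C)c1cccc(C(C)C)c1NC(=O)NCC1(c2ccc(Cl)cc2)CCCC1` is the next member: chloro in place of fluoro on an aromatic carbon. For the measured compounds named here, only one measured step exists, the exchange of methyl for fluoro from compound 1 to compound 2, and it produced no shift beyond the scatter. Going by the values given here, no measured pair shows a chloro against a fluoro at this position, so the expectation for compound 3 can rest only on that single, flat step. On that basis the step of a 1.2-fold lower number from compound 2 to compound 3 (0.06 log units; within the scatter) is expected to stay within the scatter in this assay, with no direction to favour.

Compound 3 is therefore estimated at 20 nM in this assay, with a range from 9 nM to 45 nM.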

Compound 3, half-maximal inhibitory concentration: 32 nM
For compound 3 the middle estimate is 1.6-fold (0.20 log units) below the measured one; measured number inside the range.
By their numbers in this assay, from the lowest: compounds 2, 1 and 3 (each within the scatter of the next).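

In this assay the exchange of fluoro for chloro on this aromatic carbon gives a 1.4-fold higher number from compound 2 to compound 3 (0.14 log units; within the scatter) and the exchange of methyl for chloro gives a 1.3-fold higher number from compound 1 to compound 3 (0.11 log units; within the scatter) and so all three pairs among compound 1, compound 2 and compound 3 now fail to separate. The earlier compounds shown here offered a single flat exchange at this position, whereas methyl, fluoro and chloro now form a closed set of three in which each group can stand in for either of the others with no reading of order on these numbers. No supporting measurement bears on this result, so the flat picture stands as an observation only.

The compounds shown leave open whether this position stays as flat for groups of another kind, such as an amine, a carboxylic acid, a methoxy group or a longer chain, as the set shown spans only methyl, fluoro and chloro. They also leave open whether the same three groups would behave alike elsewhere on the aromatic ring, and whether any exchange at this position can move the number beyond the scatter at all.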